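Lengthening a side chain: from compound 3 to compound 4

This account rests on a few compounds, and the source may have more. Where it says the series, first, only, none or still open, it means among the compounds named here.

Compound 1 `Cc1cn([C@@H]2O[C@@H]3COC(=O)[C@]3(OS(C)(=O)=O)[C@H]2O)c(=O)[nH]c1=O` gives >= 250000 nM in a functional assay on MT4 cells (Homo sapiens); a higher number here means that more compound is tolerated, a lower number that less compound is tolerated; this value is a limit of the assay, not a number.
Compound 2 `CCOC(=O)CNC(=O)NC1=CS(=O)(=O)O[C@@]12[C@@H](CO[Si](C)(C)C(C)(C)C)O[C@@H](n1cc(C)c(=O)n(C)c1=O)[C@@H]2O[Si](C)(C)C(C)(C)C` gives 3780 nM in this assay.
Compound 3 `Cc1cn([C@@H]2O[C@H](CO[Si](C)(C)C(C)(C)C)[C@@]3(OS(=O)(=O)C=C3NC(N)=O)[C@H]2O[Si](C)(C)C(C)(C)C)c(=O)n(C)c1=O` gives 3700 nM in this assay.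

Of the two actual numbers, compound 3 holds the lower one, but its nearest neighbour is compound 2, and the two sit within the scatter of each other, so no order between them can be claimed. For compound 1 only a limit is known, and the limit of >= 250000 nM in this assay, at which 1 of the 3 values shown sits, says nothing about how far beyond it the true value lies.

Compound 4 `Cc1cn([C@@H]2O[C@H](CO[Si](C)(C)C(C)(C)C)[C@@]3(OS(=O)(=O)C=C3NCCC(N)=O)[C@H]2O[Si](C)(C)C(C)(C)C)c(=O)n(C)c1=O` has not yet been measured. It differs from compound 3 in one place, as counted from the two structures: 2-carbamoylethyl in place of carbamoyl on an amine nitrogen. For the measured compounds named here, only one measured step bears on this kind of change, a swap on a nitrogen of the same side chain: a 1.0-fold lower number from compound 2 to compound 3 (0.01 log units; within the scatter). That step stayed within the scatter, and the change to compound 4 is of similar character, so no step beyond the scatter is expected. Compound 4 is therefore expected to show a step of no change at the digits printed from compound 3 to compound 4 (within the scatter) in this assay. Compound 4 is estimated at 3700 nM, with a range from 1500 nM to 9000 nM.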

Compound 4, half-maximal cytotoxic concentration: 20000 nM
Beside the measured number, compound 4's estimate is 5.4-fold (0.73 log units) below it; the whole stated range lies below it.
By their numbers in this assay, from the lowest: compounds 3 and 2 (each within the scatter of the next); then compound 4. At a limit, above all of these: compound 1.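

Up to this point the side chain on this nitrogen seemed not to matter in this assay, because the only step there stayed within the scatter, but the only evidence available has no bearing on why the number now moves. For the compounds shown here, replacing carbamoyl on this amine nitrogen with 2-carbamoylethyl gives the first step beyond the scatter at this place (a 5.4-fold higher number from compound 3 to compound 4 (0.73 log units; beyond the scatter)), so more compound is tolerated after the change, though the step is modest. The same holds against the larger ((ethoxycarbonyl)methyl)carbamoyl group (a 5.3-fold higher number from compound 2 to compound 4 (0.72 log units; beyond the scatter)), so the two carbamoyl-type side chains sit together and the 2-carbamoylethyl chain stands apart from both.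

This single change both lengthens the chain and turns ureido into (2-carbamoylethyl)amino, and the compounds shown cannot separate those two parts of it. They also leave open how a plain amine on this nitrogen, a carboxylic acid at the end of the chain or a still longer chain would fare in this assay, and whether the number would keep rising.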